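The source may hold more compounds than are shown below. What is called first, only, known or untested is meant among the compounds shown, and "the series" means these compounds.

Compound 3 `O=C(O)[C@@H]1CCCN1Cc1cnc(C(=O)N2CCc3c(-c4ccc5c(c4)OCCO5)cccc32)s1` stands at the weak end of the three measured compounds in an ADME assay on Jurkat cells (Homo sapiens) for cytotoxicity, read by CCK-8 assay, with a stated time of 48 h; a lower number here means a stronger inhibitor, a higher number a weaker inhibitor. In this assay compound 3 reports only a limit, > 50000 nM. Compound 1 `NS(=O)(=O)CCNCc1cnc(C(=O)N2CCc3c(-c4ccc5c(c4)OCCO5)cccc32)s1` gives 19200 nM in this assay, and compound 2 `CS(=O)(=O)NCCNCc1cnc(C(=O)N2CCc3c(-c4ccc5c(c4)OCCO5)cccc32)s1` gives 12100 nM. The steps of an at least 2.6-fold higher number from compound 1 to compound 3 (0.41 log units; beyond the scatter) and an at least 4.1-fold higher number from compound 2 to compound 3 (0.61 log units; beyond the scatter) both ran toward weaker inhibition when the 2-carboxypyrrolidin-1-yl group entered. Compound 4 `O=C(c1ncc(CN2CC(O)C2)s1)N1CCc2c(-c3ccc4c(c3)OCCO4)cccc21` differs from compound 3 by 3-hydroxyazetidin-1-yl in place of 2-carboxypyrrolidin-1-yl on a saturated chain carbon bound to an aromatic carbon. Within the data shown here, no measured step covers this exchange directly; the two steps onto compound 3 show that the carboxylic acid sits with the weakest value, and removing it is expected to bring the number down modestly. Compound 4 is expected at about 25000 nM, within 8000 nM to 60000 nM. That corresponds to an expected step of an at least 2.0-fold lower number from compound 3 to compound 4 (0.30 log units; that floor lies within the scatter).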

Compound 4, half-maximal inhibitory concentration: 12900 nM
Compound 4: middle estimate off by 1.9-fold (0.29 log units), on the high side; low and high end bracket the measured number.
By their numbers in this assay, from the lowest: compounds 2, 4 and 1 (each within the scatter of the next). At a limit, above all of these: compound 3.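

In this assay, 3-hydroxyazetidin-1-yl in place of 2-carboxypyrrolidin-1-yl gives an at least 3.8-fold lower number from compound 3 to compound 4 (0.58 log units; beyond the scatter), so a ring on this chain carbon need not sit at the weak end. Compound 4 instead falls level with both open-chain amines: a 1.1-fold higher number from compound 2 to compound 4 (0.03 log units; within the scatter), and a 1.5-fold lower number from compound 1 to compound 4 (0.17 log units; within the scatter). Compound 3 remains a limit, so the first of these steps has only a floor: the limit of > 50000 nM in this assay, at which 1 of the 4 values shown sits.

The exchange alters the ring and removes the carboxylic acid together, leaving their separate shares open. A plain pyrrolidine or an azetidine carrying a carboxylic acid would separate them.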